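A few compounds are considered here, and "the series" means these few. Any claim that something is new, unique, unknown or untested is made for them only; others in the source may bear on it.

Measured in an ADME assay on MIA PaCa-2 cells (Homo sapiens) for cytotoxicity, read by MTT assay, with a stated time of 72 h (a lower number here means a stronger inhibitor, a higher number a weaker inhibitor), each entry being a limit of the assay:

- Compound 1 `COc1ccc(C2=C(c3cc(OC)c(OC)c(OC)c3)C(=O)CC2C)cc1C(=O)O`: > 100 ug/mL
- Compound 2 `C=CCOc1cc(C2=C(c3cc(OC)c(OC)c(OC)c3)C(=O)C(O)C2)ccc1OC`: > 100 ug/mL
- Compound 3 `COC(=O)c1cc(C2=C(c3cc(OC)c(OC)c(OC)c3)C(=O)CC2O[SiH2]C(C)(C)C)ccc1OC`: > 100 ug/mL

None of these three entries is a number, so no order can be drawn among the compounds. On these data alone, compound 3 stands at the limit of > 100 ug/mL in this assay, at which 3 of the 3 values shown sit, and its true position is unknown.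

The next compound to be tested, compound 4 `COCOc1cc(C2=C(c3cc(OC)c(OC)c(OC)c3)C(=O)CC2O[SiH2]C(C)(C)C)ccc1OC`, differs from compound 3 in one place: methoxymethoxy in place of methoxycarbonyl on an aromatic carbon. Methoxymethoxy replaces methoxycarbonyl on an aromatic carbon, ortho to a methoxy group and meta to a large group, and the rest of the structure stays the same.

Going by the values given here, no measured pair in this set differs in a single place, so the data give no direct size for such a change. All three measured compounds sit at the same limit, so the expectation is that compound 4 also stays weak in this assay, and another limit is the likeliest report. The expected at least 1.2-fold lower number from compound 3 to compound 4 (0.09 log units; that floor lies within the scatter) is small, and if it can be seen at all it should point towards a stronger inhibitor. For compound 4 the estimated value is 80 ug/mL, with an expected range of 15 ug/mL to 150 ug/mL.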

Compound 4, half-maximal inhibitory concentration: 50 ug/mL
For compound 4 the middle estimate is 1.6-fold (0.20 log units) above the measured one; the measured number falls inside the stated range.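

In this assay, compound 4 is the first compound here to give a number rather than a limit, so methoxymethoxy in place of methoxycarbonyl on this aromatic carbon, ortho to a methoxy group, is the first change to lift a compound off the value shared by the others: the limit of > 100 ug/mL in this assay, at which 3 of the 4 values shown sit.

Going by these compounds alone, the change gives an at least 2.0-fold lower number from compound 3 to compound 4 (0.30 log units; that floor lies within the scatter), which shows a direction that the earlier compounds could not show, though only as a floor within the usual scatter. The two groups have the same counts of heavy atoms and hydrogen-bond acceptors and differ in the double bond outside aromatic rings, which leaves with methoxycarbonyl, so those counts alone do not separate compound 3 from compound 4.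

On these data alone, the entry for compound 3 is a limit, and the true size of the step to compound 4 remains open, as does which feature of the exchanged groups matters. Also open, as far as these compounds go, is whether an amine or a longer ether chain in the same place, with the rest of compound 4 unchanged, would give a lower number in this assay.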